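This account rests on a few compounds, and the source may have more. Where it says the series, first, only, none or still open, it means among the compounds named here.

Measured compounds:
compound 1, `FC(F)(F)c1ccc(Nc2ncnc3c2CCN(c2ncccc2C(F)(F)F)C3)cc1`: 71 nM
compound 2, `CSc1ccccc1Nc1nc2c(Nc3ccc(C(F)(F)F)cc3)ncnc2s1`: 26 nM
compound 3, `CSc1ccc(Nc2ncnc3sc(Nc4c(Cl)cccc4Cl)nc23)cc1`: 12 nM

All three were tested in a functional assay on HEK293 cells for antagonist activity at transient receptor potential cation channel subfamily V member 1 (Rattus norvegicus), read by calcium flux; a lower number here means a stronger inhibitor, a higher number a weaker inhibitor. Compound 3 gives the lowest number of the three, and its gaps to both other compounds lie beyond the usual scatter: the nearest is compound 2 with 26 nM, the furthest compound 1 with 71 nM. Compound 4, `O=S(=O)(c1ccc(Nc2ncnc3sc(Nc4c(Cl)cccc4Cl)nc23)cc1)N1CCCC1`, differs from compound 3 in one place, ((pyrrolidin-1-yl)sulfonyl in place of methylsulfanyl on an aromatic carbon), placed on an aromatic carbon, para to a large group. Among the measured compounds shown here, no pair of measured compounds isolates this change, so the expectation rests on compound 3 alone. A modest shift toward a weaker inhibitor is expected, with the step from compound 3 to compound 4 estimated at a 2.5-fold higher number from compound 3 to compound 4 (0.40 log units; beyond the scatter). Compound 4 is therefore expected to give about 30 nM, in a range from 6 nM to 150 nM.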

Compound 4, half-maximal inhibitory concentration: 0.5 nM
Estimate against measurement, compound 4: 60-fold (1.78 log units) above; measured number below the stated range.
By their numbers in this assay, from the lowest: compound 4; then compound 3; then compound 2; then compound 1.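

In this assay, the aromatic carbon para to a large group turns out to be a sensitive place: exchanging methylsulfanyl for (pyrrolidin-1-yl)sulfonyl gives a 24-fold lower number from compound 3 to compound 4 (1.38 log units; beyond the scatter), a large step toward a stronger inhibitor. So this position can carry a much larger group, with a sulfonyl and a five-membered ring, and the inhibitor still gains strongly. Nothing measured here accounts for the size of this step.

This single step cannot separate the part played by the sulfonyl from that of the pyrrolidine ring. A methylsulfonyl group, or a sulfonyl bearing a piperidine or morpholine ring, at this position would leave that question open no longer.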